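This account rests on a few compounds, and the source may have more. Where it says the series, first, only, none or still open, it means among the compounds named here.

Working notes on the series.

Compound 3 `COc1ccc(F)cc1CNCCCNc1ccnc2cc(Cc3ccc(F)cc3Cl)ccc12` gives 23 10^-6 cm/s in an ADME assay for permeability, using PAMPA, with a stated time of 30 min, at pH 7.4; on this read-out lower numbers stand for lower permeability and higher numbers for higher permeability. Compound 1 `COc1cccc(CNCCCNc2ccnc3cc(Cc4ccccc4)ccc23)c1O` gives 23 10^-6 cm/s in this assay, and compound 2 `COc1ccc(F)cc1CNCCCNc1ccnc2cc(CCc3ccccc3)ccc12` gives 23 10^-6 cm/s there, so compound 3 stands level with both at the digits shown, within the scatter of each.

The step to compound 4 `COc1ccc(F)cc1CNCCCNc1ccnc2cc(Cc3ccccc3)ccc12` is phenyl in place of 2-chloro-4-fluorophenyl on a saturated chain carbon bound to an aromatic carbon. Among the compounds with values here, the one measured step touching this position is the change from compound 2 to compound 3, which read no change at the digits printed from compound 2 to compound 3 (within the scatter), the reverse substitution at the same saturated chain carbon. Compound 1 and compound 4 share the phenyl at this position and differ elsewhere, and both compounds sit at the same value as compound 3. Nothing measured here moved this assay beyond its scatter, so no step beyond the scatter is expected from no change at the digits printed from compound 3 to compound 4 (within the scatter).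

Compound 4 is therefore expected to give about 23 10^-6 cm/s in this assay, with a range of 12 10^-6 cm/s to 46 10^-6 cm/s.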

Compound 4, apparent permeability: 23 10^-6 cm/s
Estimate against measurement, compound 4: no gap at the digits printed, and the stated range covers the measured number.
By their numbers in this assay, from the lowest: compounds 1, 2, 3 and 4 (each within the scatter of the next).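

The halogens on this ring now have a direct read: with 2-chloro-4-fluorobenzyl going to benzyl, this assay shows no change at the digits printed from compound 3 to compound 4 (within the scatter) and does not separate the two groups. At the same place, phenyl in place of benzyl gives no change at the digits printed from compound 2 to compound 4 (within the scatter), so the shorter group also stays level with the longer one. The first step read at the other end of the molecule, on a saturated chain carbon bound to an amine nitrogen, gives no change at the digits printed from compound 1 to compound 4 (within the scatter) and likewise stays level.

Still open, going by these compounds, is whether a carboxylic acid or an amine on the saturated chain carbon bound to an aromatic carbon would move this assay beyond the scatter. No supporting evidence accounts for this level read-out.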